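From Bromo to Methoxy on the Shared Core

This account rests on a few compounds, and the source may have more. Where it says the series, first, only, none or still open, it means among the compounds named here.

Compound 1 `CC1(C)[C@H]2CC[C@]1(C)N(Cc1cn(-c3cccc(F)c3)nn1)C(=O)C2` gives 80 nM
Compound 2 `CC1(C)[C@H]2CC[C@]1(C)N(Cc1cn(-c3cccc(C#N)c3)nn1)C(=O)C2` gives 40 nM
Compound 3 `CC1(C)[C@H]2CC[C@]1(C)N(Cc1cn(-c3cccc(Br)c3)nn1)C(=O)C2` gives 20 nM

These three compounds differ only in one group on the aromatic ring, and all were tested in a functional assay on HepG2 cells (Homo sapiens) for inhibition, read by MTT assay, with a stated time of 24 h; on this read-out higher numbers stand for weaker inhibition and lower numbers for stronger inhibition. Two steps show where compound 3 stands: a 2.0-fold lower number from compound 2 to compound 3 (0.30 log units; within the scatter), and a 4.0-fold lower number from compound 1 to compound 3 (0.60 log units; beyond the scatter). Compound 4 `COc1cccc(-n2cc(CN3C(=O)C[C@@H]4CC[C@@]3(C)C4(C)C)nn2)c1` has methoxy in place of bromo on an aromatic carbon.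

For the measured compounds named here, no measured compound carries methoxy, so the only guide is the size of the swaps already seen at this place. Besides the two steps above, there is a 2.0-fold lower number from compound 1 to compound 2 (0.30 log units; within the scatter). All of these are small to modest, so a large jump seems unlikely. Neither other group gave a result that could be told apart from compound 3 in the favourable direction, so a modest rise in the number is expected, one that may stay within the scatter. The expected change is a 2.3-fold higher number from compound 3 to compound 4 (0.35 log units; beyond the scatter). The estimate for compound 4 is 45 nM, within an expected range from 15 nM to 130 nM.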

Compound 4, half-maximal inhibitory concentration: 70 nM
Compound 4: middle estimate off by 1.6-fold (0.19 log units), on the low side; the measured number falls inside the stated range.
By their numbers in this assay, from the lowest: compounds 3, 2, 4 and 1 (each within the scatter of the next, the first and the last beyond it).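

Methoxy brings oxygen to this place on the ring, and in this assay this swap gives a 3.5-fold higher number from compound 3 to compound 4 (0.54 log units; beyond the scatter), so bromo cannot be replaced by methoxy without a measurable loss on this read-out. The other two steps, a 1.8-fold higher number from compound 2 to compound 4 (0.24 log units; within the scatter) and a 1.1-fold lower number from compound 1 to compound 4 (0.06 log units; within the scatter), are too small to separate methoxy from cyano or fluoro, which leaves bromo clear of fluoro and methoxy but still not of cyano. No measurement available here explains why bromo and methoxy differ in this way.

The four groups shown are only a small sample of what could sit at this place. Going by these compounds, how an amine, a carboxylic acid, a longer chain such as ethoxy or another halogen such as iodo would compare with bromo remains open.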